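Benzyl in place of allyl: an expected shift

The compounds below may be only part of what the source reports. "The series", "measured", "known", "first", "only" and "open" are said of these compounds alone.

Measured compounds:
Compound 1, `C=CCn1c(=O)c2c(ncn2C)n(CC=C)c1=O`, gives 18000 nM in an assay on cell membranes with adenosine receptor A1 (Rattus norvegicus) as the target; on this read-out lower numbers stand for stronger inhibition and higher numbers for weaker inhibition.
Compound 2, `CCCn1c(=O)c2c(ncn2CCC)n(CCC)c1=O`, gives 2600 nM in this assay.
Compound 3, `C=CCn1cnc2c1c(=O)n(CCC)c(=O)n2CCC`, gives 1900 nM in this assay.

Among these three, compound 3 gives the lowest number. Its nearest neighbour is compound 2, and the step of a 1.4-fold lower number from compound 2 to compound 3 (0.14 log units; within the scatter) lies within the scatter, so the two cannot be told apart. Compound 1 stands far above both, and its number compared with that of compound 3 shows a gap beyond the scatter.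

Compound 4, `CCCn1c(=O)c2c(ncn2Cc2ccccc2)n(CCC)c1=O`, has not been measured in this assay. It differs from compound 3 in one place: phenyl in place of vinyl on a saturated chain carbon bound to an aromatic nitrogen.

Going by the values given here, the only measured step at this same place is the step of a 1.4-fold lower number from compound 2 to compound 3 (0.14 log units; within the scatter), a small change that stayed within the scatter. Among the compounds with values here, that step swapped a small group for another small group; the change to compound 4 brings in a much larger group, for which there is no measured step here. With so little to go on, the expectation is a step of a 1.6-fold higher number from compound 3 to compound 4 (0.20 log units; within the scatter) that may fall either way but is more likely to stay within the scatter than to move far.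

Compound 4 is therefore estimated at 3000 nM, with a range from 800 nM to 12000 nM.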

Compound 4, inhibition constant: 1000 nM
For compound 4 the middle estimate is 3.0-fold (0.48 log units) above the measured one; measured number inside the range.
By their numbers in this assay, from the lowest: compounds 4, 3 and 2 (each within the scatter of the next, the first and the last beyond it); then compound 1.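

In this assay, this place on the shared core accepts a group much larger than any seen there before: putting benzyl where allyl stood gives a 1.9-fold lower number from compound 3 to compound 4 (0.28 log units; within the scatter) and so leaves the two compounds indistinguishable. The earlier compounds shown here offered only a swap between two small chains, so they could not show that a whole aromatic ring would be accepted here with no loss of binding. Set against the propyl chain of compound 2, the same benzyl group gives a 2.6-fold lower number from compound 2 to compound 4 (0.41 log units; beyond the scatter) and provides the first step at this place to pass the scatter, although it is modest and compound 3 cannot be told apart from either compound.

Still open, from the compounds shown here alone, is whether a benzyl ring carrying a methoxy group or a chlorine atom, or a longer chain such as phenylethyl, would lower the number further at this place. Going by these compounds, it is equally open whether an amine or a carboxylic acid on the chain would be accepted, and no evidence at hand bears on what lies behind these numbers.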